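The source may report more compounds than this note shows. Statements on the series, on what has been measured and on what is new or still open speak of the compounds shown alone.

Notes on three measured compounds and one untested analogue, all run in a functional assay on BEL-7404 cells (Homo sapiens) for cytotoxicity, read by MTT assay, with a stated time of 72 h; a higher number here means a weaker inhibitor, a lower number a stronger inhibitor. Compound 1 `COc1ccc(NC(=O)COC(=O)/C=C/c2cc(OC)c(OCc3ccc(Cl)c(Cl)c3)c(OC)c2)cc1` gives 97800 nM in this assay. Compound 2 `CCOc1ccc(COc2c(OC)cc(/C=C/C(=O)OCC(=O)Nc3ccccc3)cc2OC)cc1` stops at the limit of this assay, > 200000 nM. Compound 3 `COc1cc(/C=C/C(=O)OCC(=O)Nc2ccc(Cl)cc2)cc(OC)c1OCc1ccc(Cl)c(Cl)c1` likewise stops at the limit, > 200000 nM, so its position is known only as a bound. Two of the three values shown sit at that bound (the limit of > 200000 nM in this assay, at which 2 of the 3 values shown sit). Going by the values given here, the single step that reaches compound 3, an at least 2.0-fold higher number from compound 1 to compound 3 (0.31 log units; beyond the scatter), is chloro in place of methoxy on an aromatic carbon. Compound 4 `CCOc1ccc(COc2c(OC)cc(/C=C/C(=O)OCC(=O)Nc3ccc(Cl)cc3)cc2OC)cc1` differs from compound 3 by 4-ethoxyphenyl in place of 3,4-dichlorophenyl on a saturated chain carbon bound to an oxygen on an aromatic ring. Among the compounds with values here, no measured step isolates this change; what is known is that compound 2, which carries the same 4-ethoxybenzyl group, also gives only a bound. The expectation for compound 4 is therefore no shift that the assay could resolve, a step that the limit leaves unreadable from compound 3 to compound 4, and most probably another limit. Compound 4 is estimated at 250000 nM, expected to fall between 100000 nM and 600000 nM.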

Compound 4, half-maximal inhibitory concentration: > 200000 nM
Compound 4: only a limit was reported; the forecaster's own chance of this, stated with the estimate: 80%; the middle value does not contradict the limit.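

In this assay compound 4 gives > 200000 nM, which is a limit, so the steps to it from compound 2 and from compound 3 cannot be read. The compounds shown leave open whether the chloro or the 4-ethoxyphenyl change shifts the number at all.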